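Para Bromo for Fluoro in an Isoxazoline Cytotoxicity Series

A few compounds are considered here, and "the series" means these few. Any claim that something is new, unique, unknown or untested is made for them only; others in the source may bear on it.

Compound 1, `OC[C@@H]1C[C@H](CO)[C@@H]2C(c3ccccc3Cl)=NO[C@H]12`: 33.8 ug/mL
Compound 2, `OC[C@@H]1C[C@H](CO)[C@@H]2C(c3ccc(F)cc3)=NO[C@H]12`: 17.8 ug/mL
Compound 3, `OC[C@@H]1C[C@H](CO)[C@@H]2C(c3ccc4ccccc4c3)=NO[C@H]12`: 14.3 ug/mL

Three compounds sharing one bicyclic core were measured in a functional assay on HT-29 cells (Homo sapiens) for cytotoxicity, read by MTT assay, with a stated time of 48 h; on this read-out lower numbers stand for stronger inhibition and higher numbers for weaker inhibition. Compound 1 gives 33.8 ug/mL, compound 2 gives 17.8 ug/mL, and compound 3 gives 14.3 ug/mL. Compound 2 holds the second highest of the three numbers, yet its gap to compound 3 and its gap to compound 1 both lie within the usual scatter of this assay, so the three cannot be separated with confidence.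

Compound 4, `OC[C@@H]1C[C@H](CO)[C@@H]2C(c3ccc(Br)cc3)=NO[C@H]12`, has not yet been measured. It differs from compound 2 in one place: bromo in place of fluoro on an aromatic carbon. For the measured compounds named here, no measured pair in the set differs in exactly one group, so no step of a similar kind is available for comparison. The three measured values span a narrow range, and the author therefore expects a step from compound 2 to compound 4 of a 1.2-fold lower number from compound 2 to compound 4 (0.07 log units; within the scatter), small and not beyond the scatter, in this assay. Compound 4 is estimated at 15 ug/mL, with a range from 6 ug/mL to 36 ug/mL.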

Compound 4, half-maximal inhibitory concentration: 37.3 ug/mL
Compound 4: the middle estimate sits 2.5-fold (0.40 log units) below what was measured; the whole stated range lies below it.
By their numbers in this assay, from the lowest: compounds 3, 2, 1 and 4 (each within the scatter of the next, the first and the last beyond it).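

In this assay, bromo in place of fluoro on an aromatic carbon, para to a large group, gives a 2.1-fold higher number from compound 2 to compound 4 (0.32 log units; beyond the scatter). For the compounds shown here, this modest step, the only one here between compounds that differ in one place, shows that the read-out responds to the identity of the halogen at this position, with bromo giving the weaker inhibition of the pair. No measurement bearing on why this change moves the value is available.

The compounds shown leave open whether other groups on the same aromatic carbon, such as an amine, a methoxy group or a carboxylic acid, would move the value in the same direction or the opposite one. They also leave open whether this step would hold if the two hydroxymethyl groups on the shared core were replaced.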